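The source may report more compounds than this note shows. Statements on the series, on what has been measured and on what is new or still open speak of the compounds shown alone.

Measured in an ADME assay on microsomes from liver (Canis lupus familiaris) for metabolic stability, read by LC-MS, using NADPH, with a stated time of 10 min, tested at 0.1 uM; on this read-out higher numbers stand for fast clearance and lower numbers for slow clearance:
Compound 1 `O=C(NCCCCc1ccccc1)c1cccc(C2SCC(=O)N2c2cccc(-c3c[nH]nn3)c2)c1`: 226 mL.min-1.g-1
Compound 2 `O=C(NCCCCc1ccccc1)c1cccc(C2SCC(=O)N2c2ccccn2)c1`: 492 mL.min-1.g-1

Compound 2 has the higher of these two numbers. The unmeasured compound 3 `O=C(NCCCCc1ccccc1)c1cccc(C2SCC(=O)N2c2cccc(F)c2)c1` differs from it in one place: 3-fluorophenyl in place of pyridin-2-yl on an amide-type nitrogen in a ring. Among the compounds with values here, only one measured step bears on that place, a 2.2-fold higher number from compound 1 to compound 2 (0.34 log units; beyond the scatter), and it is modest. That step involved a different incoming group, so it is only a rough guide. No step beyond the scatter is therefore expected in this assay, and any drift would probably be slightly upward. The expected step is a 1.1-fold higher number from compound 2 to compound 3 (0.05 log units; within the scatter). For compound 3 the estimate is 550 mL.min-1.g-1, with an expected range of 270 mL.min-1.g-1 to 1100 mL.min-1.g-1.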

Compound 3, intrinsic clearance in microsomes: 837 mL.min-1.g-1
Estimate against measurement, compound 3: 1.5-fold (0.18 log units) below, and the stated range covers the measured number.
By their numbers in this assay, from the lowest: compound 1; then compounds 2 and 3 (each within the scatter of the next).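

In this assay, 3-fluorophenyl in place of pyridin-2-yl on the amide-type nitrogen gives a 1.7-fold higher number from compound 2 to compound 3 (0.23 log units; within the scatter), so these two groups cannot be told apart here. Fluoro in place of 1H-1,2,3-triazol-4-yl on an aromatic carbon gives a 3.7-fold higher number from compound 1 to compound 3 (0.57 log units; beyond the scatter), which leaves compound 1 as the only one of the three set clearly apart, with the lowest clearance. Nothing available explains either step. On these data alone, it remains open whether that lower number is specific to the triazolyl group, or whether a carboxylic acid or an amine on the same aromatic carbon would give a similar number.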